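Compound 3 to compound 4: methoxy replaced by hydrogen

This account rests on a few compounds, and the source may have more. Where it says the series, first, only, none or still open, it means among the compounds named here.

Measured so far in a functional assay on HL-60 cells (Homo sapiens) for antiproliferative activity; a lower number here means a stronger inhibitor, a higher number a weaker inhibitor:
Compound 1 `Oc1cccc2nccc(O)c12` gives > 30000 nM as a limit
Compound 2 `COc1cc2c(c(O)c1OC)c(=O)ccn2C` gives > 30000 nM as a limit
Compound 3 `COc1cc2c(c(OC)c1OC)c(=O)ccn2C` gives > 30000 nM as a limit

Compound 3 stands only at a limit and has no number, like the other two compounds. Compound 4 `COc1cc2c(=O)ccn(C)c2cc1OC` carries hydrogen in place of methoxy on an aromatic carbon and keeps the rest of the core. Among the compounds with values here, the one measured step at this same methoxy group is a step that the two limits leave unreadable from compound 2 to compound 3 and offers no size to carry over. Compound 1, compound 2 and compound 3 all sit at the limit of > 30000 nM in this assay, at which 3 of the 3 values shown sit, and the expectation rests on that. No gain beyond the scatter is expected in this assay and no direction can be read. The estimated step is a step that the limit leaves unreadable from compound 3 to compound 4 and it is probably unreadable. For compound 4 the expected value is 40000 nM with an estimated range from 10000 nM to 100000 nM and a limit is the likeliest report.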

Compound 4, half-maximal inhibitory concentration: > 30000 nM
Compound 4: no number, only a limit; the forecaster's own chance of this, stated with the estimate: 80%; the middle value lies beyond the limit too.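

In this assay compound 4 gives > 30000 nM, which is a limit. Its steps from compound 2 and from compound 3 cannot be read. The compounds shown leave open which change to the shared core, if any, would give a measurable value in this assay.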